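Estimating a tert-butyl swap on the benzyl-type ring

The compounds below may be only part of what the source reports. "The series", "measured", "known", "first", "only" and "open" are said of these compounds alone.

Measured so far in a functional assay on MCF-10A cells (Homo sapiens) for antiproliferative activity, with a stated time of 48 h; a lower number here means that less compound is needed, a higher number that more compound is needed for the effect:
- compound 1 `COc1ccc2nc(C)cc(NCc3ccccc3)c2c1` gives 28600 nM
- compound 2 `COc1ccc2nc(C)cc(NCc3cccnc3)c2c1` gives 49300 nM
- compound 3 `COc1ccc2nc(C)cc(NCc3ccc(C)cc3)c2c1` gives 22400 nM

Compound 3 cannot be told apart from compound 1 on these numbers, as the measured change is a 1.3-fold lower number from compound 1 to compound 3 (0.11 log units; within the scatter). It does stand apart from compound 2, with a 2.2-fold lower number from compound 2 to compound 3 (0.34 log units; beyond the scatter).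

The next compound is compound 4 `COc1ccc2nc(C)cc(NCc3ccc(C(C)(C)C)cc3)c2c1`, which has tert-butyl in place of methyl on an aromatic carbon. The closest evidence is the change that put the methyl on that ring, a 1.3-fold lower number from compound 1 to compound 3 (0.11 log units; within the scatter). The swap of the whole ring, a 2.2-fold lower number from compound 2 to compound 3 (0.34 log units; beyond the scatter), bears on it less directly and is also modest. For the measured compounds named here, no measured compound carries a tert-butyl, so this is an extrapolation, and the range must stay wide.

In this assay, no change beyond the scatter is expected, with at most a slight drift towards a lower number. The expected change is a 1.2-fold lower number from compound 3 to compound 4 (0.09 log units; within the scatter). For compound 4 the estimated value is 18000 nM, with an expected range from 7000 nM to 45000 nM.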

Compound 4, half-maximal effective concentration: 7000 nM
Estimate against measurement, compound 4: 2.6-fold (0.41 log units) above; measured number inside the range.
By their numbers in this assay, from the lowest: compound 4; then compounds 3, 1 and 2 (each within the scatter of the next, the first and the last beyond it).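

In this assay, this carbon on the six-membered aromatic ring of carbon only proves able to shift the number: methyl stayed within the scatter of hydrogen, but tert-butyl gives a 3.2-fold lower number from compound 3 to compound 4 (0.51 log units; beyond the scatter) and so moves clearly beyond it. Set against hydrogen at the same carbon, tert-butyl gives a 4.1-fold lower number from compound 1 to compound 4 (0.61 log units; beyond the scatter) and thus a step beyond the scatter that compound 3 did not show. No measurement here explains why the larger group lowers the number.

On these data alone, with only hydrogen, methyl and tert-butyl at this carbon, it stays open whether an isopropyl would give a number closer to that of compound 3 or compound 4, or whether the lower number needs tert-butyl itself. As far as these compounds go, how a methoxy or a carboxylic acid would behave at the same carbon also remains open.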